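Cytotoxicity notes on compounds 1 to 4

A few compounds are considered here, and "the series" means these few. Any claim that something is new, unique, unknown or untested is made for them only; others in the source may bear on it.

Measured so far:
compound 1 `COc1ccc(-c2cc(/C=C/C(=O)c3ccc(OC)c(OC)c3)[nH]n2)cc1`: 90%
compound 2 `COc1cc(-c2cc(/C=C/C(=O)c3ccc(Cl)c(Cl)c3)[nH]n2)cc(OC)c1OC`: 91%
compound 3 `COc1ccc(-c2cc(/C=C/C(=O)c3ccc(N)cc3)[nH]n2)cc1OC`: 91%

In a functional assay on MDA-MB-468 cells (Homo sapiens) for cytotoxicity, read by sulforhodamine B assay, with a stated time of 48 h, tested at 0.1 uM (a higher number here means a weaker effect of the compound at the concentration tested, a lower number a stronger effect), compound 2 gives 91%, level with compound 3 at the digits shown and together the highest of the three numbers; compound 1 sits slightly lower, within the scatter. For the measured compounds named here, no two measured compounds differ in a single place, so no step is known yet. Compound 4 `COc1ccc(C(=O)/C=C/c2cc(-c3cc(OC)c(OC)c(OC)c3)n[nH]2)cc1OC` is next. Its change from compound 2: 3,4-dimethoxyphenyl in place of 3,4-dichlorophenyl on a carbonyl carbon. Compound 1 also carries a 3,4-dimethoxyphenyl on its carbonyl carbon and gives 90% in this assay. In this assay compound 4 is therefore expected at 90%, within 80% to 100%. The expected step of a number 1 percentage points lower from compound 2 to compound 4 (within the scatter) is none beyond the scatter.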

Compound 4, a percentage reported as activity, at one concentration (the size of the read-out at that concentration, not a potency): 89%
For compound 4 the middle estimate is 1 percentage points above the measured one; low and high end bracket the measured number.
By their numbers in this assay, from the lowest: compounds 4, 1, 2 and 3 (each within the scatter of the next).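

In this assay, for the compounds shown here, 3,4-dimethoxyphenyl in place of 3,4-dichlorophenyl on a carbonyl carbon gives a number 2 percentage points lower from compound 2 to compound 4 (within the scatter), the first single-place step. At the one concentration tested, this position therefore does not separate these two aryl groups, although the entering group brings oxygen where the leaving group has chlorine. No other measurement bears on this result.

From the compounds shown here alone, it remains open whether an amine or a carboxylic acid at this position would give a step beyond the scatter. Going by these compounds, whether the two groups also stay level at other concentrations remains open too.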